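Five-Membered Amine Ring in Place of Six

The compounds below may be only part of what the source reports. "The series", "measured", "known", "first", "only" and "open" are said of these compounds alone.

Compound 3 `O=S(=O)(c1cccc(F)c1)c1cn(C2CCCNC2)c2ccccc12` shows the lowest of the three numbers in an assay on HeLa cells for displacement of a labelled ligand from 5-hydroxytryptamine receptor 6 (Homo sapiens), with a stated time of 2 h; a lower number here means a stronger inhibitor, a higher number a weaker inhibitor: compound 3 gives 6 nM. Its nearest neighbour is compound 1 `COc1ccc2c(c1)c(S(=O)(=O)c1cccc(F)c1)cn2C1CCCNC1`, which in this assay gives 10.7 nM; the step of a 1.8-fold lower number from compound 1 to compound 3 (0.25 log units; within the scatter) lies within the scatter, so the two are not separated. Compound 2 `O=S(=O)(c1ccccc1)c1cn(C2CCN(Cc3ccccc3)C2)c2ccccc12` stands furthest away, giving 113 nM in this assay. Compound 4 `O=S(=O)(c1cccc(F)c1)c1cn(C2CCNC2)c2ccccc12` has not yet been measured. It differs from compound 3 in one place: pyrrolidin-3-yl in place of piperidin-3-yl on an aromatic nitrogen. Among the compounds with values here, no measured step changes the amine ring alone. Compound 2 carries a pyrrolidin-3-yl ring as well but differs from compound 3 elsewhere too; the number for compound 2, 113 nM, therefore shows only that this whole combination gives a higher number, and cannot be read as the effect of ring size by itself. Within the data shown here, with no step bearing directly on the change, the expectation for this assay is a modest shift toward a higher number, of a size that may not exceed the scatter. Compound 4 is therefore estimated at 15 nM, within a range from 4 nM to 60 nM. This estimate corresponds to an expected step of a 2.5-fold higher number from compound 3 to compound 4 (0.40 log units; beyond the scatter).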

Compound 4, inhibition constant: 4.7 nM
For compound 4 the middle estimate is 3.2-fold (0.50 log units) above the measured one; the measured number falls inside the stated range.
By their numbers in this assay, from the lowest: compounds 4, 3 and 1 (each within the scatter of the next, the first and the last beyond it); then compound 2.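

In this assay, the change of the amine ring alone can now be read directly, and a 1.3-fold lower number from compound 3 to compound 4 (0.11 log units; within the scatter) does not separate the two compounds. On the aromatic nitrogen of the shared core, the five-membered pyrrolidin-3-yl ring and the six-membered piperidin-3-yl ring therefore give numbers within the scatter of each other, at least with the fluorinated sulfonyl group and no methoxy group on the core. No measurement given here accounts for this lack of separation between the two ring sizes.

The compounds shown leave open whether an azetidine ring or a seven-membered azepane ring on the same aromatic nitrogen would also remain within the scatter of compound 3, and what a methyl group on the amine nitrogen of the pyrrolidin-3-yl ring would do in this assay. Within the data shown here, they also offer no single-change step that would separate the contributions of the benzyl group and the missing fluorine to the number for compound 2, which gives 113 nM in the same assay.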